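Two Diaryl Ureas Measured, a Third Awaits Its Number

The compounds below may be only part of what the source reports. "The series", "measured", "known", "first", "only" and "open" are said of these compounds alone.

Compound 1 `COc1cc(Cl)cc(-c2nn(-c3cccc(NC(=O)Nc4ccc(Cl)c(C(F)(F)F)c4)c3)cc2-c2ccncc2)c1`: 89%
Compound 2 `COc1cc(Cl)cc(-c2nn(-c3cccc(NC(=O)Nc4ccc(Cl)c(Cl)c4)c3)cc2-c2ccncc2)c1`: 99%

In a functional assay on Hs-578T cells (Homo sapiens) for inhibition, read by sulforhodamine B assay, with a stated time of 48 h, tested at 1 uM (on this read-out higher numbers stand for a weaker effect at the one concentration tested and lower numbers for a stronger effect), compound 2 gives 99%, the highest of the two numbers at hand, with compound 1 as its nearest neighbour at 89%. For the measured compounds named here, the only measured step, a number 10 percentage points higher from compound 1 to compound 2 (within the scatter), lies within the scatter, so neither compound can be called stronger than the other.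

Compound 3 `COc1cc(Cl)cc(-c2nn(-c3cccc(NC(=O)Nc4cccc(C(F)(F)F)c4)c3)cc2-c2ccncc2)c1` has not yet been measured. It differs from compound 2 as follows: 3-(trifluoromethyl)phenyl in place of 3,4-dichlorophenyl on an amide-type nitrogen. Going by the values given here, no measured step matches this change; the one step on hand, from compound 1 to compound 2, swaps a single group on the same ring and produced no movement beyond the scatter. On that basis compound 3 is expected to show a step of a number 4 percentage points lower from compound 2 to compound 3 (within the scatter) in this assay, that is, nothing beyond the scatter. The estimate for compound 3 is 95%, with a range from 80% to 108%.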

Compound 3, a percentage reported as activity, at one concentration (the size of the read-out at that concentration, not a potency): 90%
For compound 3 the middle estimate is 5 percentage points above the measured one; measured number inside the range.
By their numbers in this assay, from the lowest: compounds 1, 3 and 2 (each within the scatter of the next).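

The exchange of 3,4-dichlorophenyl for 3-(trifluoromethyl)phenyl on the amide-type nitrogen gives, in this assay, a number 9 percentage points lower from compound 2 to compound 3 (within the scatter), so replacing both ring substituents at once shows no difference beyond the scatter, where the earlier pair had tested only one. Hydrogen in place of chloro on an aromatic carbon gives a number 1 percentage points higher from compound 1 to compound 3 (within the scatter), so across these compounds the chloro group can be present or absent with no difference that can be read. No measurement on hand offers an explanation for these results.

Going by these compounds, the three compounds carry only chloro and trifluoromethyl groups on this ring, so it remains open whether an amine, a carboxylic acid or a methoxy group there would shift the number. Changes elsewhere on the shared core also remain open.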